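From Oxolan-2-yl to Cyclohexyl at the Ring Amine

This account rests on a few compounds, and the source may have more. Where it says the series, first, only, none or still open, it means among the compounds named here.

Of the compounds shown here, two that share one core have been measured in an assay on membranes from brain for displacement of a labelled ligand from Sigma non-opioid intracellular receptor 1 (Cavia porcellus), read by scintillation counting, with a stated time of 120 min; on this read-out lower numbers stand for stronger inhibition and higher numbers for weaker inhibition. Compound 1 `CCN1CCN(CCC(=O)Nc2nc3c(C)cccc3s2)CC1` gives 543 nM in this assay. Compound 2 `Cc1cccc2sc(NC(=O)CCN3CCN(CC4CCCO4)CC3)nc12` gives 109 nM in this assay, the lower of the two numbers. Going by the values given here, the single measured step, a 5.0-fold lower number from compound 1 to compound 2 (0.70 log units; beyond the scatter), came from placing oxolan-2-yl in place of methyl on a saturated chain carbon bound to an amine nitrogen in a ring.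

Compound 3 `Cc1cccc2sc(NC(=O)CCN3CCN(CC4CCCCC4)CC3)nc12` differs from compound 2 at that same place: cyclohexyl in place of oxolan-2-yl on a saturated chain carbon bound to an amine nitrogen in a ring. Among the compounds with values here, no measured pair shows this exact exchange, so the step from compound 1 to compound 2 is the only guide. It shows that a larger ring group at this place gave a clearly lower number, and cyclohexyl is likewise a ring group, though the oxygen that enters in compound 2 is absent in compound 3. For compound 3 the expected step is therefore a 1.5-fold lower number from compound 2 to compound 3 (0.16 log units; within the scatter), small and possibly within the scatter. The estimate for compound 3 in this assay is 75 nM, with a range from 20 nM to 280 nM.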

Compound 3, inhibition constant: 35 nM
For compound 3 the middle estimate is 2.1-fold (0.33 log units) above the measured one, and the stated range covers the measured number.
By their numbers in this assay, from the lowest: compound 3; then compound 2; then compound 1.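

In this assay the new result shows that the kind of ring matters at this place, on a saturated chain carbon bound to an amine nitrogen in a ring: the earlier pair compared a ring group only with methyl, whereas a 3.1-fold lower number from compound 2 to compound 3 (0.49 log units; beyond the scatter) separates two ring groups from each other. Measured against the methyl end of the series, cyclohexyl gives a 16-fold lower number from compound 1 to compound 3 (1.19 log units; beyond the scatter) and so carries the series further than oxolan-2-yl did, which makes this single position able to move the number by a large step while the shared core stays the same. The change from compound 2 to compound 3 is not a clean test of one feature, however, since a five-membered ring with one hetero atom leaves and a six-membered ring of carbon only enters, so ring size and the oxygen change together.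

A cyclopentyl group, a five-membered ring of carbon only, or an oxan-2-yl group, a six-membered ring that keeps the oxygen, would be needed to pull those two changes apart, and an amine on the ring would be a further untested variation. Nothing available here accounts for why the number falls at this position.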